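A few compounds are considered here, and "the series" means these few. Any claim that something is new, unique, unknown or untested is made for them only; others in the source may bear on it.

Measured so far:
Compound 1, `O=C(O)CCc1ccc(OCc2noc(-c3ccccc3)n2)cc1`, gives 2650 nM.
Compound 2, `O=C(O)CCc1ccc(OCc2nc(-c3ccccc3)no2)c(Cl)c1`, gives 13100 nM.

Both numbers come from a functional assay on CHO cells for agonist activity at Free fatty acid receptor 1 (Homo sapiens), read by FLIPR and calcium flux, in the presence of a further agent that is not named here; a higher number here means that more compound is needed for the effect, a lower number that less compound is needed. Within this small set compound 2 gives the highest number, so it needs the most compound for the effect; its nearest neighbour is compound 1, whose number is lower by a gap that lies beyond the usual scatter. For the measured compounds named here, nothing else about the pair is computed here, and no step between measured compounds is available to calibrate against.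

The next compound, compound 3, `O=C(O)CCc1ccc(OCc2nc(-c3cccc(C(F)(F)F)c3)no2)c(Cl)c1`, differs from compound 2 in one place: trifluoromethyl in place of hydrogen on an aromatic carbon
The new group sits on the six-membered aromatic ring of carbon only, meta to a large group, and carries no donors, acceptors or charge.

Going by the values given here, no measured step of this kind exists in the set, so the expectation rests on the change alone. A modest move toward a lower number in this assay seems plausible, but a result within the scatter cannot be ruled out. Compound 3 is therefore expected to give roughly 5000 nM, within a range from 1500 nM to 18000 nM, which would mean an expected step of a 2.6-fold lower number from compound 2 to compound 3 (0.42 log units; beyond the scatter).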

Compound 3, half-maximal effective concentration: 30100 nM
Compound 3: the middle estimate sits 6.0-fold (0.78 log units) below what was measured, and the stated range ends below it.
By their numbers in this assay, from the lowest: compound 1; then compound 2; then compound 3.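

In this assay, for the compounds shown here, this is the first single change that can be read on its own, and replacing hydrogen with trifluoromethyl here gives a 2.3-fold higher number from compound 2 to compound 3 (0.36 log units; beyond the scatter). So this aromatic carbon, on the six-membered aromatic ring of carbon only and meta to a large group, does not accept the new group without a modest loss: more compound is needed for the effect, and the step is larger than repeat measurements alone would be expected to produce. The incoming group has 4 heavy atoms, no hydrogen-bond donors or acceptors and no net charge, but no measurement shown here explains the rise.

The compounds shown leave open whether a single fluorine atom, a methyl group or a methoxy group on this same carbon would also raise the number, or whether the step is specific to trifluoromethyl. They also leave open whether trifluoromethyl on a different carbon of the same ring would give a higher number, a lower one or one within the scatter of compound 2.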